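A Smaller Substituent on the Aryl Group of Compound 3

The source may hold more compounds than are shown below. What is called first, only, known or untested is meant among the compounds shown, and "the series" means these compounds.

Measured so far:
Compound 1 `COc1cc(/C=C/C(C)=O)ccc1OCc1cn(-c2c(F)cccc2F)nn1` gives 24200 nM in a functional assay on PC-3 cells (Homo sapiens) for antiproliferative activity, read by MTT assay, with a stated time of 48 h; on this read-out lower numbers stand for stronger inhibition and higher numbers for weaker inhibition.
Compound 2 `COc1cc(/C=C/C(C)=O)ccc1OCc1cn(-c2ccccc2CO)nn1` gives 50300 nM in this assay.
Compound 3 `COc1cc(/C=C/C(C)=O)ccc1OCc1cn(-c2ccc(/N=N/c3ccccc3)cc2)nn1` gives 42100 nM in this assay.

All three numbers are high, and compound 3 sits between the other two, within the scatter of each. Compound 4 `COc1cc(/C=C/C(C)=O)ccc1OCc1cn(-c2ccc([N+](=O)[O-])cc2)nn1` differs from compound 3 by a group of 3 heavy atoms (1 nitrogen, 2 oxygen; no ring) in place of a group of 8 heavy atoms (6 carbon, 2 nitrogen; one six-membered aromatic ring of carbon only), on an aromatic carbon. Among the compounds with values here, the one measured step that touches the same part of the molecule, the group on the aromatic nitrogen, is a 2.1-fold higher number from compound 1 to compound 2 (0.32 log units; beyond the scatter), a modest shift. Compound 1 and compound 3 carry very different groups there yet lie within the scatter of each other, so little change is expected here. The estimated step is a 1.2-fold lower number from compound 3 to compound 4 (0.08 log units; within the scatter). Compound 4 is expected to give about 35000 nM, within 12000 nM to 100000 nM.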

Compound 4, half-maximal inhibitory concentration: 46700 nM
The estimate for compound 4 lay 1.3-fold (0.13 log units) below the measured number; the range from low to high includes it.
By their numbers in this assay, from the lowest: compounds 1, 3, 4 and 2 (each within the scatter of the next, the first and the last beyond it).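

Nitro in place of the group of 8 heavy atoms gives a 1.1-fold higher number from compound 3 to compound 4 (0.05 log units; within the scatter) in this assay, so at this place a much smaller group leaves the read-out unresolved from the larger one. The change of the whole aryl group gives a 1.1-fold lower number from compound 2 to compound 4 (0.03 log units; within the scatter) and a 1.9-fold higher number from compound 1 to compound 4 (0.29 log units; within the scatter), so compound 4 cannot be told from either, although compound 1 and compound 2 lie beyond the scatter of each other. Nothing available explains this flat result.

As far as these compounds go, whether an amine or a carboxylic acid at this place would shift the number beyond the scatter remains open.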